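A few compounds are considered here, and "the series" means these few. Any claim that something is new, unique, unknown or untested is made for them only; others in the source may bear on it.

Measured compounds:
compound 1, `C=CC(=O)N1CC[C@H](N2C(=O)N(c3ccccc3)Cc3cnc(Nc4cccc(N5CCN(C)CC5)c4)nc32)C1`: 714 ug/mL in a physicochemical assay for solubility, read by HPLC, in phosphate buffer, measured as thermodynamic solubility, with a stated time of 24 h, at pH 6.8; on this read-out lower numbers stand for lower solubility and higher numbers for higher solubility
compound 2, `C=CC(=O)N1CC[C@H](N2C(=O)N(c3ccccc3)Cc3cnc(Nc4ccc(N5CCN(C)CC5)cc4OC)nc32)C1`: 1540 ug/mL in this assay
compound 3, `C=CC(=O)N1CC[C@H](N2C(=O)N(c3ccccc3)Cc3cnc(Nc4ccc(N5CCN(C)CC5)c(OC)c4)nc32)C1`: 256 ug/mL in this assay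

Compound 2 gives the highest number of the three in this assay; compound 1 and compound 3 both sit lower, each beyond the scatter, compound 3 the furthest. Compound 4, `C=CC(=O)N1CC[C@H](N2C(=O)N(Cc3ccccc3)Cc3cnc(Nc4ccc(N5CCN(C)CC5)cc4OC)nc32)C1`, keeps the core of compound 2 and differs from it by benzyl in place of phenyl on an amide-type nitrogen in a ring. Among the measured compounds shown here, no measured pair shows this change, so its effect is unknown here. The expected step of a 1.5-fold lower number from compound 2 to compound 4 (0.19 log units; within the scatter) is small, a modest drop or none beyond the scatter. Compound 4 is therefore estimated at 1000 ug/mL in this assay, within a range of 400 ug/mL to 2500 ug/mL.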

Compound 4, solubility: 107 ug/mL
The estimate for compound 4 lay 9.3-fold (0.97 log units) above the measured number, outside the stated range (below it).
By their numbers in this assay, from the lowest: compound 4; then compound 3; then compound 1; then compound 2.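

Position notes: the amide-type nitrogen in a ring proves highly sensitive in this assay, with benzyl in place of phenyl giving a 14-fold lower number from compound 2 to compound 4 (1.16 log units; beyond the scatter) as the first step read at this position. Both groups hold one six-membered aromatic ring of carbon only, so the step arises without any change in ring type. Nothing available accounts for the step.

Open: whether a phenethyl chain, a small methyl group or a benzyl carrying an amine would behave like benzyl, and whether the step recurs with the aryl amine substitution of compound 1 or compound 3.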